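Taking one chloro off compound 3

The source may hold more compounds than are shown below. What is called first, only, known or untested is meant among the compounds shown, and "the series" means these compounds.

In a functional assay on A549 cells (Homo sapiens) for antiproliferative activity, read by MTT assay, with a stated time of 48 h (on this read-out lower numbers stand for stronger inhibition and higher numbers for weaker inhibition), compound 1 `Cc1ccc(C(=O)/C=C/c2cc(Cl)cc(Cl)c2Oc2c([N+](=O)[O-])cc(C(F)(F)F)cc2[N+](=O)[O-])cc1` gives 10.1 ug/mL, compound 2 `COc1ccc(C(=O)/C=C/c2cccc(Cl)c2Oc2c([N+](=O)[O-])cc(C(F)(F)F)cc2[N+](=O)[O-])cc1` gives 11.5 ug/mL and compound 3 `O=C(/C=C/c1cc(Cl)cc(Cl)c1Oc1c([N+](=O)[O-])cc(C(F)(F)F)cc1[N+](=O)[O-])c1ccc(F)cc1` gives 29.4 ug/mL, the highest number of the three. Compound 4 `O=C(/C=C/c1cccc(Cl)c1Oc1c([N+](=O)[O-])cc(C(F)(F)F)cc1[N+](=O)[O-])c1ccc(F)cc1` differs from compound 3 in one place: hydrogen in place of chloro on an aromatic carbon. This is hydrogen in place of chloro on an aromatic carbon. Among the measured compounds shown here, no measured step shows this change. For the measured compounds named here, the only measured step, a 2.9-fold higher number from compound 1 to compound 3 (0.46 log units; beyond the scatter), is modest but concerns fluoro in place of methyl, a change elsewhere in the molecule. Compound 2 also lacks this chloro, but it differs from compound 1 in a second place too, so its value cannot isolate the change. The expected step is therefore small, a 1.3-fold lower number from compound 3 to compound 4 (0.11 log units; within the scatter), and not beyond the scatter. Compound 4 is estimated at 23 ug/mL, with an expected range of 10 ug/mL to 50 ug/mL.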

Compound 4, half-maximal inhibitory concentration: 23.8 ug/mL
The estimate for compound 4 lay 1.0-fold (0.01 log units) below the measured number; the range from low to high includes it.
By their numbers in this assay, from the lowest: compounds 1 and 2 (each within the scatter of the next); then compounds 4 and 3 (each within the scatter of the next).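

In this assay the chloro meta to a 2-((4-fluorophenyl)carbonyl)ethenyl group can be replaced by hydrogen with a 1.2-fold lower number from compound 3 to compound 4 (0.09 log units; within the scatter) as the result, so with fluoro at the far end this position shows no effect beyond the scatter. With that chloro absent, fluoro in place of methoxy gives a 2.1-fold higher number from compound 2 to compound 4 (0.32 log units; beyond the scatter) as a modest step, so the far end still moves the number. Nothing available explains either step. On these data alone, whether an amine or a nitrile at this position would shift the number remains open, as does whether the chloro matters as little with methyl or methoxy at the far end.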